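The source may hold more compounds than are shown below. What is called first, only, known or untested is meant among the compounds shown, and "the series" means these compounds.

Within the data shown here, in an ADME assay on the whole organism (plasma, Mus musculus) for pharmacokinetics, read by LC-MS, at a dose of 30 mg/kg by the oral route (on this read-out lower numbers stand for lower exposure and higher numbers for higher exposure at the dose given), compound 3 `NCc1cc(Oc2cccc(C(=O)N3CC[C@@H](O)C3)c2)nc(C(F)(F)F)c1` gives 5130 nM, the only number in this set. Two related compounds carry no result in this assay. Compound 1 `NCc1cc(Oc2cccc(Oc3ccccc3)c2)nc(C(F)(F)F)c1` is recorded there as "not determined" (no result reported), and compound 2 `NCc1cc(Oc2cccc(C(=O)NCc3cc4ccccc4s3)c2)nc(C(F)(F)F)c1` likewise is recorded as "not determined" (no result reported). Compound 3 is therefore the single point of reference for the whole series.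

Compound 4 `NCc1cc(Oc2cccc(C(=O)NCCS(N)(=O)=O)c2)nc(C(F)(F)F)c1` shares the core of compound 3 and differs in one place, at the carbonyl carbon that sits on the aromatic ring:

(2-sulfamoylethyl)amino in place of 3-hydroxypyrrolidin-1-yl on a carbonyl carbon

A ring group with one hydrogen-bond donor and one acceptor gives way to an open chain carrying two donors and two acceptors. Among the measured compounds shown here, no pair of measured compounds shows how such a change plays out in this assay, so the size and direction of the step are uncertain. Compound 4 is expected to come out somewhat lower than compound 3, with a step of a 1.7-fold lower number from compound 3 to compound 4 (0.23 log units; within the scatter), though a result within the usual scatter would not surprise. Compound 4 is estimated to reach 3000 nM, within a range from 800 nM to 12000 nM.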

Compound 4, maximal plasma concentration: 1040 nM
For compound 4 the middle estimate is 2.9-fold (0.46 log units) above the measured one; measured number inside the range.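

In this assay, among these compounds, replacing 3-hydroxypyrrolidin-1-yl with (2-sulfamoylethyl)amino on the carbonyl carbon gives a 4.9-fold lower number from compound 3 to compound 4 (0.69 log units; beyond the scatter), the first step in this set that can be read at all. It shows that this position is not indifferent: the group on the carbonyl carbon can change exposure by more than repeat measurements would scatter. Nothing measured here says why the number falls, and this one step cannot separate losing the ring from gaining the sulfamoyl group.

Going by these compounds, it remains open whether a plain pyrrolidine without the hydroxyl, or an open chain ending in a hydroxyl group instead of the sulfamoyl group, would stay nearer compound 3. On these data alone, a carboxylic acid or a longer chain at this place is equally open.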